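Methoxy for methyl on the aryl of compound 2

The source may report more compounds than this note shows. Statements on the series, on what has been measured and on what is new or still open speak of the compounds shown alone.

Compound 1, `C/C(=C\c1cc(-c2ccc(C)nc2)co1)C(N)=O`: in a functional assay on MCF7 cells (Homo sapiens) for cytotoxicity, read by CCK-8 assay, with a stated time of 24 h (a lower number here means a stronger inhibitor, a higher number a weaker inhibitor), compound 1 gives 10200 nM.
Compound 2, `C/C(=C\c1cc(-c2ccc(C)cc2)cs1)C(N)=O`: in this assay compound 2 gives > 50000 nM, which is a limit of the assay and not a number.
Compound 3, `C/C(=C\c1cccc(-c2ccccc2)c1)C(N)=O`: in this assay compound 3 gives 6540 nM.

Where compound 2 stands: its result is a limit of the assay, so only a bound is known, and it sits among the weaker readings of the three, with the limit of > 50000 nM in this assay, at which 1 of the 3 values shown sits, describing exactly this situation. Within the data shown here, no two of the measured compounds differ in one place, so no measured step is available, and the values of compound 1 and compound 3 can only be read side by side.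

Compound 4, `COc1ccc(-c2csc(/C=C(\C)C(N)=O)c2)cc1`, is the next compound to be measured in this assay. It differs from compound 2 by methoxy in place of methyl on an aromatic carbon. With no measured step of this kind in the series, the expected change from compound 2 to compound 4 is held modest and toward a stronger inhibitor, yet not far beyond the scatter, since compound 2 itself is only bounded. The estimated step is an at least 1.6-fold lower number from compound 2 to compound 4 (0.22 log units; that floor lies within the scatter). For compound 4 the expected value in this assay is 30000 nM, within a range from 8000 nM to 100000 nM, with a real chance that only a limit is returned again.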

Compound 4, half-maximal inhibitory concentration: > 50000 nM
Compound 4 gave a limit, no number (the forecaster's own chance of this, stated with the estimate: 50%); middle value at least 1.6-fold (0.22 log units) away from the limit.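

No step can be read from compound 2 to compound 4, since both results are limits of the assay and neither is a number: the limit of > 50000 nM in this assay, at which 2 of the 4 values shown sit. Still open, from the compounds shown here alone, is whether methoxy in place of methyl on an aromatic carbon changes the reading in this assay at all, as neither compound has a measured value.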